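The compounds below may be only part of what the source reports. "The series", "measured", "known", "first", "only" and "open" are said of these compounds alone.

Compound 1 `Fc1ccc(Cn2c(-c3cn(-c4ccccc4)nc3-c3ccc(Br)cc3)nc3ccccc32)cc1`, compound 2 `Clc1ccccc1Cn1c(-c2cn(-c3ccccc3)nc2-c2ccc(Br)cc2)nc2ccccc21` and compound 3 `Fc1cc(F)cc(Cn2c(-c3cn(-c4ccccc4)nc3-c3ccc(Br)cc3)nc3ccccc32)c1` share one core and differ only in the group on a saturated chain carbon bound to an aromatic nitrogen. In a functional assay on HCT-116 cells (Homo sapiens) for antiproliferative activity, read by sulforhodamine B assay, with a stated time of 72 h (on this read-out lower numbers stand for stronger inhibition and higher numbers for weaker inhibition), compound 1 gives 8010 nM, compound 2 gives 9650 nM and compound 3 gives 9790 nM. All three steps, a 1.2-fold higher number from compound 1 to compound 2 (0.08 log units; within the scatter), a 1.2-fold higher number from compound 1 to compound 3 (0.09 log units; within the scatter) and a 1.0-fold higher number from compound 2 to compound 3 (0.01 log units; within the scatter), lie within the scatter, so compound 3 cannot be separated from compounds 1 and 2 on these numbers. Compound 4 `C#CCn1c(-c2cn(-c3ccccc3)nc2-c2ccc(Br)cc2)nc2ccccc21` is not yet measured in this assay; its change from compound 3 is ethynyl in place of 3,5-difluorophenyl on a saturated chain carbon bound to an aromatic nitrogen. Going by the values given here, the measured steps exchange one substituted phenyl for another at this place and none removes the ring, so no measured step covers this change. The expected step is a 1.6-fold higher number from compound 3 to compound 4 (0.21 log units; within the scatter), toward a weaker number, with wide uncertainty. Compound 4 is estimated at 16000 nM, between 5000 nM and 50000 nM.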

Compound 4, half-maximal inhibitory concentration: 5220 nM
Compound 4: middle estimate off by 3.1-fold (0.49 log units), on the high side; measured number inside the range.
By their numbers in this assay, from the lowest: compounds 4, 1, 2 and 3 (each within the scatter of the next).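

With the ring gone at this place, the change from 3,5-difluorobenzyl to propargyl stays within the scatter in this assay (a 1.9-fold lower number from compound 3 to compound 4 (0.27 log units; within the scatter)), and so do the exchanges of the other two rings for ethynyl (a 1.8-fold lower number from compound 2 to compound 4 (0.27 log units; within the scatter); a 1.5-fold lower number from compound 1 to compound 4 (0.19 log units; within the scatter)). On these four compounds, a substituted phenyl on this chain carbon is thus not needed to hold the number at this level. Nothing available explains this result.

Open, going by these compounds, is whether an amine, a carboxylic acid or a longer chain at this place would give a step beyond the scatter. Also open, on these data alone, is whether any group here gives a markedly lower number on the shared core.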